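The source may hold more compounds than are shown below. What is called first, only, known or untested is meant among the compounds shown, and "the series" means these compounds.

Compound 1 `Cc1cccc(CN2Cc3c(NC(=O)c4ccccc4)n[nH]c3C2(C)C)c1` gives 1100 nM in an assay on Sf21 cells for inhibition of high affinity nerve growth factor receptor (Homo sapiens), read by HTRF, with a stated time of 30 min, in the presence of a further agent that is not named here; on this read-out lower numbers stand for stronger inhibition and higher numbers for weaker inhibition. Compound 2 `CC1(C)c2[nH]nc(NC(=O)c3ccccc3)c2CN1Cc1cccc(C#N)c1` gives 980 nM in this assay.

For the measured compounds named here, compound 2 holds the lower of the two numbers measured so far, yet the step of a 1.1-fold lower number from compound 1 to compound 2 (0.05 log units; within the scatter) lies within the usual scatter, so the two compounds cannot be told apart on these data. Compound 3 `CC1(C)c2[nH]nc(NC(=O)c3ccccc3)c2CN1Cc1cccc(I)c1` differs from compound 2 by iodo in place of cyano on an aromatic carbon. Going by the values given here, only one measured step bears on this position: a 1.1-fold lower number from compound 1 to compound 2 (0.05 log units; within the scatter), which exchanged one small group for another on the same aromatic carbon and produced no change beyond the scatter. Among the compounds with values here, the data hold no example of a halogen at this place, so the expectation rests on that single step alone. Compound 3 is therefore expected to give about 900 nM in this assay, with a likely range from 350 nM to 2500 nM. For compound 3 the estimated step of a 1.1-fold lower number from compound 2 to compound 3 (0.04 log units; within the scatter) is expected to remain within the scatter.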

Compound 3, half-maximal inhibitory concentration: 1360 nM
Estimate against measurement, compound 3: 1.5-fold (0.18 log units) below, within the range that was stated.
By their numbers in this assay, from the lowest: compounds 2, 1 and 3 (each within the scatter of the next).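

Iodo on this aromatic carbon brings the first halogen to the position, and in this assay it gives a 1.4-fold higher number from compound 2 to compound 3 (0.14 log units; within the scatter) when it takes the place of cyano. Set against methyl, the same group gives a 1.2-fold higher number from compound 1 to compound 3 (0.09 log units; within the scatter) and so adds a second comparison that stays inside the scatter. Methyl, cyano and iodo therefore cannot be told apart at this place in the three compounds, even though iodo counts no hydrogen-bond acceptor and cyano counts one. Nothing available here offers an explanation for these numbers.

From the compounds shown here alone, whether an amine, a carboxylic acid or a longer chain on this carbon would give a step beyond the scatter remains open. Also open, going by these compounds, is how any of these groups would read on another carbon of the same six-membered aromatic ring.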